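This account rests on a few compounds, and the source may have more. Where it says the series, first, only, none or still open, it means among the compounds named here.

Measured compounds:
Compound 1 `O=S(=O)(c1ccc(F)cc1)N1CCC2(CC1)OOC1(CCCC1)OO2`: in a functional assay on Huh-7 cells (Homo sapiens) for cytotoxicity, read by MTT assay, with a stated time of 72 h (a lower number here means that less compound is tolerated, a higher number that more compound is tolerated), compound 1 gives > 100 ug/mL, a limit of the assay rather than a number.
Compound 2 `O=S(=O)(c1ccc(F)cc1)N1CCC2(CC1)OOC1(CCCCCC1)OO2`: in this assay compound 2 gives > 100 ug/mL, again a limit.
Compound 3 `O=S(=O)(c1ccc(Br)cc1F)N1CCC2(CC1)OOC1(CCCC1)OO2`: in this assay compound 3 gives > 100 ug/mL, also a limit.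

Compound 3 arises from compound 1 by one change, (4-bromo-2-fluorophenyl in place of 4-fluorophenyl on a sulfonyl sulfur). The step that the two limits leave unreadable from compound 1 to compound 3 cannot be sized because both ends sit at the limit of > 100 ug/mL in this assay, at which 3 of the 3 values shown sit. Compound 2 differs from compound 1 in its core; that difference is not broken down here.

Compound 4 `O=S(=O)(c1ccc(Br)cc1F)N1CCC2(CC1)OOC1(CCCCCC1)OO2` is not yet measured. It arises from compound 2 by the same change at the same place, (4-bromo-2-fluorophenyl in place of 4-fluorophenyl on a sulfonyl sulfur). Among the measured compounds shown here, the only precedent for this change is the pair of compound 1 and compound 3, where no size was readable. For the measured compounds named here, with every value in this assay so far sitting at the limit, the step expected from compound 2 to compound 4 is a step that the limit leaves unreadable from compound 2 to compound 4, which is an estimate rather than a reading. For compound 4 in this assay the expected result is 150 ug/mL, estimated between 100 ug/mL and 400 ug/mL, most likely reported only as a limit.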

Compound 4, half-maximal cytotoxic concentration: > 100 ug/mL
Compound 4 gave a limit, no number; the forecaster's own chance of this, stated with the estimate: 85%; the middle value is on the limit's open side.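

No step can be read in this assay between compound 2 and compound 4, because both results are limits rather than numbers: the limit of > 100 ug/mL in this assay, at which 4 of the 4 values shown sit.
The compounds shown leave open where each half-maximal cytotoxic concentration lies, and whether 4-bromo-2-fluorophenyl in place of 4-fluorophenyl changes it at all.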